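Adding a methoxy group to an aminopyrazolopyridinone compound

The source may report more compounds than this note shows. Statements on the series, on what has been measured and on what is new or still open speak of the compounds shown alone.

Measured compounds:
- Compound 2, `Cn1nc(N)c2c(=O)[nH]c(-c3ccccc3)cc21`: 11%
- Compound 3, `Cn1nc(N)c2c(=O)[nH]c(-c3ccccn3)cc21`: 9%
- Compound 1, `COc1ccc(-c2cc3[nH]nc(N)c3c(=O)[nH]2)cc1`: 7%

All three were tested in an assay on isolated protein for inhibition of MAP kinase-activated protein kinase 5 (Homo sapiens), read by mobility shift assay, tested at 30 uM; on this read-out lower numbers stand for less inhibition and higher numbers for more inhibition at the one concentration tested (going by the name of the read-out). Compound 2 is the reference point here. Its distance to compound 3 is a number 2 percentage points lower from compound 2 to compound 3 (within the scatter), and the gap to compound 1 is also within the scatter, so the three numbers cannot be told apart with confidence.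

Compound 4, `COc1ccc(-c2cc3c(c(N)nn3C)c(=O)[nH]2)cc1`, has not yet been measured. It differs from compound 2 by one change: methoxy in place of hydrogen on an aromatic carbon.

Among the compounds with values here, only one measured step exists, the one from compound 2 to compound 3, and it concerns a pyridin-2-yl in place of phenyl, not a methoxy group; it was within the scatter. Compound 1 does carry a methoxy group, but it also differs from compound 2 elsewhere, so the two values show only that both lie within the scatter of each other. Within the data shown here, no measured step therefore speaks directly to the change in hand, and nothing in the data suggests a shift beyond the scatter in this assay.

Compound 4 is expected to give 9%, with a range from 0% to 20%. The expected step is a number 2 percentage points lower from compound 2 to compound 4 (within the scatter), no movement beyond the scatter.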

Compound 4, a percentage reported as inhibition, at one concentration (the size of the read-out at that concentration, not a potency): 16%
The estimate for compound 4 lay 7 percentage points below the measured number; measured number inside the range.
By their numbers in this assay, from the lowest: compounds 1, 3, 2 and 4 (each within the scatter of the next).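

In this assay, within the data shown here, methoxy in place of hydrogen, on an aromatic carbon para to a large group, now has a measured step of its own, which the earlier compounds could not supply: the change gives a number 5 percentage points higher from compound 2 to compound 4 (within the scatter) and so, at this position, adding the methoxy produces no shift that can be told apart from ordinary scatter. A second single change, methyl in place of hydrogen on an aromatic nitrogen with the methoxy already present, gives a number 9 percentage points higher from compound 1 to compound 4 (within the scatter) and so it too stays inside the scatter, even though it is the larger of the two new steps. Nothing measured alongside these compounds offers an explanation for either step.

On these data alone, whether an amine, a carboxylic acid or a longer chain such as butoxy at this same place would move the number beyond the scatter remains open. Also open is how any of these compounds would behave at other concentrations, since a reading at one concentration gives no potency.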